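Notes on the step from compound 1 to compound 4

The source may hold more compounds than are shown below. What is called first, only, known or untested is meant among the compounds shown, and "the series" means these compounds.

Measured in a functional assay on PC-3 cells (Homo sapiens) for inhibition, read by sulforhodamine B assay, with a stated time of 48 h; on this read-out higher numbers stand for weaker inhibition of growth and lower numbers for stronger inhibition of growth:
- compound 1 `COc1cc(-c2nn(-c3cccc(NC(=O)Nc4ccc(Cl)c(Cl)c4)c3)cc2-c2ccncc2)ccc1Cl`: 554 nM
- compound 2 `O=C(Nc1cccc(-n2cc(-c3ccncc3)c(-c3ccc(Cl)c(O)c3)n2)c1)Nc1ccc(Cl)c(Cl)c1`: 834 nM
- compound 3 `O=C(Nc1cccc(-n2cc(-c3ccncc3)c(-c3ccc(Cl)c(O)c3)n2)c1)Nc1cc(C(F)(F)F)cc(C(F)(F)F)c1`: 319 nM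

Compound 1 lies within the scatter of both compound 2 and compound 3, so it cannot be ranked against either. Compound 4 `COc1cc(-c2nn(-c3cccc(NC(=O)c4ccccc4)c3)cc2-c2ccncc2)ccc1Cl`, not yet measured, has phenyl in place of (3,4-dichlorophenyl)amino on a carbonyl carbon.

Among the measured compounds shown here, the only measured step is a 1.5-fold higher number from compound 1 to compound 2 (0.18 log units; within the scatter). It concerns hydrogen in place of methyl on an oxygen on an aromatic ring, away from the site of this change, so it says little here. The nearest evidence is indirect: compound 2 gives 834 nM and compound 3 gives 319 nM, with different groups at that end. All three measured compounds keep an amino link on that carbonyl carbon, and none carries plain phenyl there, so this is an extrapolation. A modest loss in this assay is expected, with low confidence. The expected change is a 2.7-fold higher number from compound 1 to compound 4 (0.43 log units; beyond the scatter). For compound 4 the estimated value is 1500 nM, with an expected range of 400 nM to 6000 nM.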

Compound 4, concentration for 50% growth inhibition: 426 nM
Compound 4: the middle estimate sits 3.5-fold (0.55 log units) above what was measured, within the range that was stated.
By their numbers in this assay, from the lowest: compounds 3, 4, 1 and 2 (each within the scatter of the next, the first and the last beyond it).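

In this assay, phenyl in place of (3,4-dichlorophenyl)amino on a carbonyl carbon gives a 1.3-fold lower number from compound 1 to compound 4 (0.11 log units; within the scatter). The chlorine atoms and the hydrogen-bond donor of the leaving group are therefore not required at this position for growth inhibition at this level. Compounds 1, 2 and 3 could not show this, as all of them keep an amino link on that carbonyl carbon. Nothing available explains why the two groups read alike.

Left open is whether an aromatic ring is needed here at all: a cyclohexyl ring, a short alkyl chain or a benzyl group on the carbonyl carbon would test this. From the compounds shown here alone, it is also open whether substituents on the new phenyl, such as chlorine or trifluoromethyl, change the reading.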